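Dimethoxyphenyl Replaces Fluorostyryl on a Bile Acid Receptor Ligand

The source may report more compounds than this note shows. Statements on the series, on what has been measured and on what is new or still open speak of the compounds shown alone.

Compound 1: `COC(=O)/C=C/c1cccc(N(Cc2ccc(/C=C/c3ccccc3F)cc2)C(=O)C2CCCCC2)c1`, 64 nM
Compound 2: `COC(=O)/C=C/c1cccc(N(Cc2ccc(/C=C/c3ccccc3F)cc2)C(=O)NC(C)C)c1`, 431 nM
Compound 3: `COC(=O)/C=C/c1cccc(N(Cc2ccc(-c3cccc(OC(F)(F)F)c3)cc2)C(=O)C(C)C)c1`, 247 nM

In an assay on isolated protein with Bile acid receptor (Homo sapiens) as the target (on this read-out lower numbers stand for an effect already at smaller amounts and higher numbers for an effect only at larger amounts of compound), compound 2 gives 431 nM, the largest number among the three measured compounds. Compound 3 gives 247 nM, which lies within the scatter of compound 2, so the two cannot be told apart. Within the data shown here, compound 1 gives 64 nM, and the only single-point step measured so far, a 6.7-fold higher number from compound 1 to compound 2 (0.83 log units; beyond the scatter), concerns the group on the carbonyl carbon and nothing else.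

Compound 4, `COC(=O)/C=C/c1cccc(N(Cc2ccc(-c3c(OC)cccc3OC)cc2)C(=O)NC(C)C)c1`, differs from compound 2 at a different place: 2,6-dimethoxyphenyl in place of 2-(2-fluorophenyl)ethenyl on an aromatic carbon. Among the measured compounds shown here, no measured pair isolates this kind of change. Compound 3 carries a biaryl rather than a styryl group, but it also carries isopropyl instead of isopropylamino on the carbonyl, so its number cannot be read as a step for the aromatic position alone. The measured step therefore does not bear directly on compound 4, and nothing in the data points to a change beyond the scatter in either direction.

Compound 4 is estimated at 500 nM, with a range from 130 nM to 2000 nM. This estimate means a 1.2-fold higher number from compound 2 to compound 4 (0.06 log units; within the scatter), which is expected to stay within the scatter.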

Compound 4, half-maximal effective concentration: 561 nM
The estimate for compound 4 lay 1.1-fold (0.05 log units) below the measured number; the measured number falls inside the stated range.
By their numbers in this assay, from the lowest: compound 1; then compounds 3, 2 and 4 (each within the scatter of the next, the first and the last beyond it).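

In this assay, among these compounds, the exchange on an aromatic carbon para to a large group gives a 1.3-fold higher number from compound 2 to compound 4 (0.11 log units; within the scatter) and is the first step read at this position alone, and it stays within the scatter. With isopropylamino held on the carbonyl, 2-(2-fluorophenyl)ethenyl and 2,6-dimethoxyphenyl therefore cannot be told apart on this read-out, even though the entering group has 2 hydrogen-bond acceptors where the leaving group has 0, and the double bond outside aromatic rings is gone. No measurement offered here explains why the two groups cannot be separated in this comparison.

As far as these compounds go, the exchange has been read only with isopropylamino on the carbonyl, so it remains open whether it would also stay within the scatter on the cyclohexyl amide, where compound 1 gives 64 nM in this assay and the number is lower. Among the compounds shown here, it also remains open how far this position tolerates other kinds of group, such as a carboxylic acid, an amine or a longer alkyl chain, or a phenyl ring bearing only one methoxy group.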